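The source may report more compounds than this note shows. Statements on the series, on what has been measured and on what is new or still open speak of the compounds shown alone.

Measured so far in a functional assay on OVCAR-5 cells (Homo sapiens) for antiproliferative activity, read by sulforhodamine B assay, with a stated time of 48 h; a lower number here means a stronger inhibitor of growth, a higher number a weaker inhibitor of growth:
Compound 1 `COc1ccc(OC)c(/C=C/c2nnc(Nc3ccc(Cl)cc3)o2)c1` gives 32500 nM.
Compound 2 `COc1ccc(OC)c(/C=C/C(=O)N/N=C/c2ccc(Cl)cc2)c1` gives 10900 nM.

Of these two, compound 2 has the lower number, and the gap to compound 1 is beyond the usual scatter. Compound 3 `COc1ccc(OC)c(/C=C/C(=O)N/N=C/c2ccccc2)c1` differs from compound 2 by one change: hydrogen in place of chloro on an aromatic carbon. Within the data shown here, no measured pair shows this same change, so its size is unknown here. The step from compound 2 to compound 3 is expected to be a small rise, about at the edge of the scatter, as a 1.8-fold higher number from compound 2 to compound 3 (0.26 log units; within the scatter). For compound 3 the estimated value in this assay is 20000 nM, within a range from 8000 nM to 50000 nM.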

Compound 3, concentration for 50% growth inhibition: 18000 nM
Estimate against measurement, compound 3: 1.1-fold (0.05 log units) above; measured number inside the range.
By their numbers in this assay, from the lowest: compounds 2, 3 and 1 (each within the scatter of the next, the first and the last beyond it).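

Going from the 4-chlorophenyl to the phenyl group in this assay gives a 1.7-fold higher number from compound 2 to compound 3 (0.22 log units; within the scatter), so this assay does not tell the two groups apart. On this aromatic carbon, para to a large group, the growth inhibition seen with compound 2 therefore does not depend on the chloro. Nothing available explains this result. Going by these compounds, whether another group at this position, such as an amine or a carboxylic acid, would shift the number remains open. So does whether the same change would have a similar effect on the core of compound 1.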